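The compounds below may be only part of what the source reports. "The series", "measured", "known", "first", "only" and "open" are said of these compounds alone.

Compound 1 `CC(C)(C)OC(=O)NC1CCCN(C(=O)CN2CN(c3ccccc3)C3(CCN(C(=O)c4ccc(C5CCCCC5)cc4)CC3)C2=O)C1` gives the lowest of the two numbers seen so far: in an assay on HEK293 cells for displacement of a labelled ligand from NPC1-like intracellular cholesterol transporter 1 (Homo sapiens) (on this read-out lower numbers stand for stronger inhibition and higher numbers for weaker inhibition), compound 1 gives 4400 nM. Compound 2 `CC(C)(C)c1ccc(C(=O)N2CCC3(CC2)C(=O)N(CC(=O)N2CCC(O)CC2)CN3c2ccccc2)cc1` gives 4700 nM in this assay, which lies within the scatter of the result for compound 1, so no order between the two can be read. Compound 3 `CC1CCCN(C(=O)CN2CN(c3ccccc3)C3(CCN(C(=O)c4ccc(C5CCCCC5)cc4)CC3)C2=O)C1` has not yet been measured; compared with compound 1 it carries methyl in place of (tert-butoxycarbonyl)amino on a saturated ring carbon. For the measured compounds named here, no measured pair covers this change. Because compound 1 gives 4400 nM while the differently decorated compound 2 gives 4700 nM, little movement is expected. The step of a 1.1-fold lower number from compound 1 to compound 3 (0.04 log units; within the scatter) is expected to stay within the scatter. Compound 3 is estimated at 4000 nM, with a range from 1500 nM to 12000 nM.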

Compound 3, half-maximal inhibitory concentration: 3600 nM
Compound 3: the middle estimate sits 1.1-fold (0.05 log units) above what was measured, within the range that was stated.
By their numbers in this assay, from the lowest: compounds 3, 1 and 2 (each within the scatter of the next).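

In this assay, replacing (tert-butoxycarbonyl)amino with methyl on this saturated ring carbon gives a 1.2-fold lower number from compound 1 to compound 3 (0.09 log units; within the scatter). For the compounds shown here, this is the first single change read at this position, and a group of 8 heavy atoms, with its hydrogen-bond donor and acceptors, gives way to a single carbon without a step beyond the scatter. No measurement shown here accounts for this result. From the compounds shown here alone, whether an amine or a carboxylic acid on this ring carbon would move the number beyond the scatter remains open.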